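The source may hold more compounds than are shown below. What is called first, only, known or untested is meant among the compounds shown, and "the series" means these compounds.

Working notes on the series in a functional assay on MV4-11 cells (Homo sapiens) for antiproliferative activity, read by luminescence and CellTiter-Glo, with a stated time of 72 h (on this read-out lower numbers stand for stronger inhibition and higher numbers for weaker inhibition), start from three compounds. Compound 1 (`COc1ccc(Cn2nc(Nc3ccc(F)cc3OC)c3cc(-c4c(C)noc4C)ccc32)cc1`) stands as "not determined" (no result reported) with no result reported, and compound 2 (`COc1ccc(C)c(C2CN(Cc3ccc(F)cc3)c3nc(-c4c(C)noc4C)ncc32)c1`) stands as "not determined" (no result reported) with no result reported either. Within the data shown here, compound 3 (`CNc1cc(-c2ccc3cnn(Cc4ccc(F)cc4)c3c2)cn(C)c1=O`) gives 2390 nM and holds the only number so far, so it cannot yet be ranked against any other compound.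

Compound 4 (`CNc1cc(-c2ccc3cnn(Cc4ccc(C)cc4)c3c2)cn(C)c1=O`) has no reading yet and differs from compound 3 in one place (methyl in place of fluoro on an aromatic carbon) with methyl in place of fluoro on an aromatic carbon, so that 4-fluorobenzyl becomes 4-methylbenzyl. Among the measured compounds shown here, the series offers no step between measured compounds, so the size of this change in this assay has no direct precedent. With compound 3 at 2390 nM as the sole anchor, no shift beyond the usual scatter is expected in either direction. The expected move (a 1.1-fold lower number from compound 3 to compound 4 (0.04 log units; within the scatter)) is an estimate and not a reading. Compound 4 is estimated at 2200 nM with an expected range from 900 nM to 5500 nM once it is measured.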

Compound 4, half-maximal inhibitory concentration: 3280 nM
Estimate against measurement, compound 4: 1.5-fold (0.17 log units) below; low and high end bracket the measured number.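

In this assay, among these compounds, the first step that can be read, a 1.4-fold higher number from compound 3 to compound 4 (0.14 log units; within the scatter), stays within the scatter, so 4-fluorobenzyl and 4-methylbenzyl cannot be told apart on this read-out. At this place, on an aromatic carbon para to a large group, methyl in place of fluoro therefore gives no shift that can be separated from repeat-measurement noise, and a single pair is all that supports this reading. No measured property bears on the result, and the pair itself offers no explanation for it.

From the compounds shown here alone, it remains open whether a group of another kind at the same place, such as an amine, a carboxylic acid or a longer chain, would move the number beyond the scatter, or whether removing the substituent altogether would do so. Going by these compounds, it is also open whether the same change would behave alike on another core, such as that of compound 2, which also carries 4-fluorobenzyl but has no number to compare, so that any reading of this position remains confined to the core shared by compound 3 and compound 4.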